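The source may hold more compounds than are shown below. What is called first, only, known or untested is meant among the compounds shown, and "the series" means these compounds.

Working notes on the series. Compound 1 `CNC(=O)c1cccc(Cn2nc(C)c(NC(=O)c3ccc(COc4ccccc4C)cc3)c2C)c1` carries a 2-methylphenyl on the oxygen on a saturated carbon; in a functional assay on MIA PaCa-2 cells (Homo sapiens) for antiproliferative activity, read by MTT assay, with a stated time of 72 h (a lower number here means that less compound is needed, a higher number that more compound is needed for the effect), compound 1 gives 2100 nM. Compound 2 `CNC(=O)c1cccc(Cn2nc(C)c(NC(=O)c3ccc(COc4ccc(OC)cc4)cc3)c2C)c1` carries a 4-methoxyphenyl at that position, and in this assay compound 2 gives 8000 nM, the higher of the two numbers, its nearest neighbour being compound 1, reached through a 3.8-fold higher number from compound 1 to compound 2 (0.58 log units; beyond the scatter). Compound 3 `CNC(=O)c1cccc(Cn2nc(C)c(NC(=O)c3ccc(COc4ccc(C(F)(F)F)cc4)cc3)c2C)c1` is not yet measured; it differs from compound 2 by trifluoromethyl in place of methoxy on an aromatic carbon. For the measured compounds named here, no measured step exchanges these two groups, so the bearing is only indirect: the one step known, from compound 1 to compound 2, shows that a change on this phenoxy ring moves the number by a modest amount beyond the scatter. A shift in this assay of comparable size is therefore expected for compound 3, with a slight lean toward a lower number. The expected step for compound 3 is a 1.8-fold lower number from compound 2 to compound 3 (0.25 log units; within the scatter). The estimate for compound 3 is 4500 nM, with a range from 1500 nM to 14000 nM.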

Compound 3, half-maximal effective concentration: 800 nM
Compound 3: the middle estimate sits 5.6-fold (0.75 log units) above what was measured; measured number outside the range, below it.
By their numbers in this assay, from the lowest: compound 3; then compound 1; then compound 2.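

In this assay, exchanging methoxy for trifluoromethyl on this aromatic carbon gives a 10-fold lower number from compound 2 to compound 3 (1.00 log units; beyond the scatter), so a single group para to a large group can move the number well beyond the scatter with the rest of the molecule unchanged. The 4-(trifluoromethyl)phenyl group also stands apart from the 2-methylphenyl group, with a 2.6-fold lower number from compound 1 to compound 3 (0.42 log units; beyond the scatter); changes on this ring therefore run in both directions from compound 1, whereas the earlier step showed only a rise. Nothing available explains these steps.

The compounds shown cover only methoxy and trifluoromethyl at this aromatic carbon, so it remains open whether a nitrile, a chlorine atom or an amine there would give a number nearer compound 3 or compound 2. As far as these compounds go, whether the lower number of compound 3 extends to other cell lines also remains open.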